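A few compounds are considered here, and "the series" means these few. Any claim that something is new, unique, unknown or untested is made for them only; others in the source may bear on it.

In a functional assay on DLD-1 cells (Homo sapiens) for inhibition, read by luminescence, with a stated time of 3 days (on this read-out lower numbers stand for stronger inhibition of growth and higher numbers for weaker inhibition of growth), compound 1 `CC(=O)N1CCN(C(=O)[C@@H]2CC[C@@H](C)N2C(=O)C2=C(C(C)C)N3C(=N[C@@](C)(c4ccc(Cl)cc4)[C@H]3c3ccc(Cl)cc3)S2)C[C@@H]1C` gives 5200 nM and compound 2 `CC(C)C1=C(C(=O)N2[C@H](C)CC[C@H]2C(=O)N2CCN(C)C(C)(C)C2)SC2=N[C@@](C)(c3ccc(Cl)cc3)[C@@H](c3ccc(Cl)cc3)N21` gives 6300 nM. Among the measured compounds shown here, the one measured step, a 1.2-fold higher number from compound 1 to compound 2 (0.08 log units; within the scatter), leaves the two within the scatter of each other. Compound 3 `CC[C@@H]1CC[C@@H](C(=O)N2CCN(C(C)=O)[C@@H](C)C2)N1C(=O)C1=C(C(C)C)N2C(=N[C@@](C)(c3ccc(Cl)cc3)[C@H]2c2ccc(Cl)cc2)S1` carries methyl in place of hydrogen on a saturated chain carbon bound to a saturated ring carbon. For the measured compounds named here, the measured step lies at another place, on a carbonyl carbon, so it bears only indirectly, and no measured step covers this change. The expected change is a 1.1-fold higher number from compound 1 to compound 3 (0.02 log units; within the scatter), with nothing beyond the scatter expected in this assay. The estimate for compound 3 is 5500 nM, with an expected range of 2500 nM to 12000 nM.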

Compound 3, concentration for 50% growth inhibition: 2600 nM
Beside the measured number, compound 3's estimate is 2.1-fold (0.33 log units) above it; low and high end bracket the measured number.
By their numbers in this assay, from the lowest: compounds 3, 1 and 2 (each within the scatter of the next, the first and the last beyond it).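

Methyl in place of hydrogen on a saturated chain carbon bound to a saturated ring carbon, here methyl to ethyl, gives the first reading at this place: a 2.0-fold lower number from compound 1 to compound 3 (0.30 log units; within the scatter), so the series keeps growth inhibition of the same order with ethyl there. No available evidence bears on this result.

Open, as far as these compounds go, is whether propyl or a hydroxymethyl group at this place would go beyond the scatter. Also open, from the compounds shown here alone, is whether methyl to ethyl reads the same with the group carried on the carbonyl carbon in compound 2.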